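The source may report more compounds than this note shows. Statements on the series, on what has been measured and on what is new or still open speak of the compounds shown alone.

In a physicochemical assay for lipophilicity, read by HPLC, measured as octanol-water partition, at pH 7.2 (on this read-out lower numbers stand for lower lipophilicity and higher numbers for higher lipophilicity), compound 2 `N#Cc1ccc(NC(=O)Nc2ccc(F)c(C(F)(F)F)c2)cc1` gives 3.8 and stands highest of the two measured compounds, with compound 1 `O=C(Nc1ccc(C(=O)O)cc1)Nc1ccc(F)c(C(F)(F)F)c1` at 1.5 on the same read-out. Compound 3 `NC(=O)c1ccc(NC(=O)Nc2ccc(F)c(C(F)(F)F)c2)cc1` differs from compound 2 by one change: carbamoyl in place of cyano on an aromatic carbon on an aromatic carbon, para to a large group. Among the compounds with values here, the one measured step that bears on this is a number 2.30 log units higher from compound 1 to compound 2 (beyond the scatter) with cyano in place of carboxy on an aromatic carbon, a large step. Cyano entered in that step and leaves in the new one, so a lower number is expected in this assay for compound 3. Within the data shown here, no carbamoyl compound has been measured, so a moderate step beyond the scatter, smaller than the measured one, is assumed. The expected change is a number 0.90 log units lower from compound 2 to compound 3 (beyond the scatter) on this estimate. For compound 3 the estimated value is 2.9 with 2.4 to 3.4 as the expected range.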

Compound 3, distribution coefficient: 2.7
Beside the measured number, compound 3's estimate is 0.20 log units above it; the range from low to high includes it.
By their numbers in this assay, from the lowest: compound 1; then compound 3; then compound 2.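

Working notes on the group para to a large group: in this assay, the read-out now separates three groups at this one place, and carbamoyl in place of cyano gives a number 1.10 log units lower from compound 2 to compound 3 (beyond the scatter) as a large step beyond the scatter. Amino in place of hydroxy on the carbonyl carbon gives a number 1.20 log units higher from compound 1 to compound 3 (beyond the scatter) as a second large step, so compound 3 sits clearly apart from both compound 1 and compound 2, and a change confined to the carbonyl carbon already moves the number this far. No measurement at hand explains either step.

Still open, going by these compounds, is where an amine, a methyl ester or a longer chain would fall at this place. Also open, on these data alone, is whether the same order of carboxy, carbamoyl and cyano holds on a different core.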